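The source may report more compounds than this note shows. Statements on the series, on what has been measured and on what is new or still open speak of the compounds shown alone.

In a functional assay on CNE-2 cells (Homo sapiens) for antiproliferative activity, read by sulforhodamine B assay, with a stated time of 48 h (a lower number here means a stronger inhibitor, a higher number a weaker inhibitor), compound 1 (`COc1cccc(/C=C/C(=O)C(=Cc2cc(OC)c(OC)c(OC)c2)C(=O)/C=C/c2cccc(OC)c2OC)c1OC`) gives 400 nM while compound 2 (`COc1cc(C=C(C(=O)/C=C/c2cccc(OC)c2OC)C(=O)/C=C/c2cccc(OC)c2OC)cc(OC)c1O`) gives 300 nM as its reading. Compound 2 therefore stands level with compound 1: the gap between them (a 1.3-fold lower number from compound 1 to compound 2 (0.12 log units; within the scatter)) is too small for the two to be told apart.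

Compound 3 (`COc1ccc(C=C(C(=O)/C=C/c2cccc(OC)c2OC)C(=O)/C=C/c2cccc(OC)c2OC)cc1O`) has not yet been measured. It differs from compound 2 in one place (3-hydroxy-4-methoxyphenyl in place of 4-hydroxy-3,5-dimethoxyphenyl on a double-bonded chain carbon bound to a double-bonded chain carbon) where 3-hydroxy-4-methoxyphenyl stands in place of 4-hydroxy-3,5-dimethoxyphenyl on a double-bonded chain carbon bound to a double-bonded chain carbon.

Among the compounds with values here, only one measured step bears on this change, and only partly. Compound 2 differs from compound 1 on the same phenyl group, with hydrogen in place of methyl on an oxygen on an aromatic ring, and that step (a 1.3-fold lower number from compound 1 to compound 2 (0.12 log units; within the scatter)) stayed within the scatter. A single small step is a thin guide, so no shift beyond the scatter is expected in either direction, though the uncertainty is wide. The expected change is slight (a 1.2-fold higher number from compound 2 to compound 3 (0.07 log units; within the scatter)) and remains an estimate. The estimated value for compound 3 is 350 nM within an expected range of 120 nM to 1000 nM in this read-out.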

Compound 3, half-maximal inhibitory concentration: 220 nM
Compound 3: middle estimate off by 1.6-fold (0.20 log units), on the high side, within the range that was stated.
By their numbers in this assay, from the lowest: compounds 3, 2 and 1 (each within the scatter of the next).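

In this assay, replacing 4-hydroxy-3,5-dimethoxyphenyl with 3-hydroxy-4-methoxyphenyl on the double-bonded chain carbon gives a 1.4-fold lower number from compound 2 to compound 3 (0.13 log units; within the scatter) and so leaves the two compounds indistinguishable. Replacing 3,4,5-trimethoxyphenyl with the same 3-hydroxy-4-methoxyphenyl group gives a 1.8-fold lower number from compound 1 to compound 3 (0.26 log units; within the scatter) and also stays inside the usual spread of repeat measurements. Together with the earlier step, this shows that three differently substituted phenyl groups at this position give readings that cannot be separated, even though they differ in the number of methoxy groups and in whether a hydroxy group is present.

No independent measurement is available to explain why these readings stay so close. Still open, as far as these compounds go, is whether this position would keep the same level of activity with a different kind of group on the phenyl ring, such as an amine or a carboxylic acid, or with a plain phenyl ring carrying no oxygen groups, and whether any such change would move the reading beyond the scatter.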